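Trimming a Cyclohexyl Ring to a Tert-Butyl Group

This account rests on a few compounds, and the source may have more. Where it says the series, first, only, none or still open, it means among the compounds named here.

Compound 1, `COc1ccccc1N1CCN(C(=O)CCc2c(-c3ccc(Br)cc3)[nH]c3ccc(C)cc23)CC1`: 1 nM
Compound 2, `CC(C)N1CCN(C(=O)CCc2c(-c3ccc(Cl)cc3)n(C)c3ccc(Cl)cc23)CC1`: 13 nM
Compound 3, `Cn1c(-c2ccc(Cl)cc2)c(CCC(=O)N2CCN(CC3CCCCC3)CC2)c2cc(Cl)ccc21`: 2.9 nM

All three were tested in an assay on CHO cells with Substance-P receptor (Homo sapiens) as the target; on this read-out higher numbers stand for weaker inhibition and lower numbers for stronger inhibition. Compound 3 stands second of the three numbers: compound 1 gives 1 nM, a lower number, and compound 2 gives 13 nM, a higher one. Among the compounds with values here, the only single-point step among them is a 4.5-fold lower number from compound 2 to compound 3 (0.65 log units; beyond the scatter).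

Compound 4, `Cn1c(-c2ccc(Cl)cc2)c(CCC(=O)N2CCN(CC(C)(C)C)CC2)c2cc(Cl)ccc21`, is not yet measured. It differs from compound 3 by tert-butyl in place of cyclohexyl on a saturated chain carbon bound to an amine nitrogen in a ring. Within the data shown here, the one step that speaks to this change is a 4.5-fold lower number from compound 2 to compound 3 (0.65 log units; beyond the scatter), in which a larger group on the same ring nitrogen went with the lower number. The incoming tert-butyl group carries fewer atoms than the cyclohexyl it replaces, so compound 4 sits between compound 2 and compound 3 in this respect, and a single step is thin evidence. A modest rise in the number is expected, though one that may still fall within the scatter. Compound 4 is expected to give 6 nM, with a range from 2.5 nM to 15 nM. The expected step is a 2.1-fold higher number from compound 3 to compound 4 (0.32 log units; beyond the scatter).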

Compound 4, half-maximal inhibitory concentration: 2 nM
Compound 4: middle estimate off by 3.0-fold (0.48 log units), on the high side; measured number outside the range, below it.
By their numbers in this assay, from the lowest: compounds 1, 4 and 3 (each within the scatter of the next, the first and the last beyond it); then compound 2.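

In this assay, tert-butyl in place of cyclohexyl on a saturated chain carbon bound to an amine nitrogen in a ring gives a 1.5-fold lower number from compound 3 to compound 4 (0.16 log units; within the scatter) and so leaves the two compounds indistinguishable: in this pair, the carbon ring is not needed to reach this level. Neopentyl in place of isopropyl on an amine nitrogen in a ring gives a 6.5-fold lower number from compound 2 to compound 4 (0.81 log units; beyond the scatter) in the same assay. The earlier step to cyclohexylmethyl therefore now has a ring-free counterpart, as both groups go with a lower number than isopropyl.

Still open, from the compounds shown here alone, is whether an ethyl group, a benzyl group or a chain carrying an ether oxygen at this nitrogen would keep the number. The data offer no measurement that explains why cyclohexylmethyl and neopentyl match.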